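Pyrrolidine substituent change and mouse microsomal stability

The compounds below may be only part of what the source reports. "The series", "measured", "known", "first", "only" and "open" are said of these compounds alone.

Measured so far:
compound 1 `CSc1ccc(-c2c(C)nc3c(N4CC[C@@H](NC(C)=O)C4)cc(C)nn23)cc1` — > 95%
compound 2 `CC(=O)N[C@@H]1CCN(c2cc(C)nn3c(-c4cccc(S(=O)(=O)N(C)C)c4)c(C)nc23)C1` — > 95%
compound 3 `COc1ccc(-c2c(C)nc3c(N4CC[C@@H](NC(=O)C(F)(F)F)C4)cc(C)nn23)cc1OC` — > 95%

All three readings come from an ADME assay on microsomes from liver (Mus musculus) for metabolic stability, read by LC-MS, with NADPH named in the record, with a stated time of 60 min, tested at 1 uM, in the absence of a further agent; a lower number here means that less of the compound is left, a higher number that more of the compound is left. The reading for compound 1 is a limit of that assay, not a number. The same holds for compound 2. Compound 3 likewise reaches only a limit; it stands together with the others at the limit of > 95% in this assay, at which 3 of the 3 values shown sit, so the readings give no spread to rank against. Compound 4 `COc1ccc(-c2c(C)nc3c(N4CC[C@@H](O)C4)cc(C)nn23)cc1OC` has not yet been measured in this assay. It differs from compound 3 in one place: hydroxy in place of ((trifluoromethyl)carbonyl)amino on a saturated ring carbon. Going by the values given here, no measured compound carries the hydroxy group, so no measured step speaks to this change. The expected step of a number at least 10 percentage points lower from compound 3 to compound 4 (that floor lies within the scatter) is a small move downward from the limit, if any. Compound 4 is therefore estimated at 85%, within 60% to 95%.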

Compound 4, percent of the compound remaining: > 95%
Compound 4: a limit, no number; the forecaster's own chance of this, stated with the estimate: 45%; middle value at least 10 percentage points from the limit.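

In this assay, going by these compounds alone, the readings for compound 3 and compound 4 are both limits, not numbers, so no step between the two can be read. The compounds shown leave open whether any group on the saturated ring carbon changes the amount of compound remaining: the limit of > 95% in this assay, at which 4 of the 4 values shown sit.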